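Sulfonamide benzamides on a pyrazole core: methoxy for methyl

The source may hold more compounds than are shown below. What is called first, only, known or untested is meant among the compounds shown, and "the series" means these compounds.

Compound 1 `Cc1ccc(-n2cc(NC(=O)c3cccc(NS(=O)(=O)c4ccccc4)c3)cn2)cc1` gives 3120 nM in a functional assay on HeLa cells (Homo sapiens) for inhibition, read by MTT assay, with a stated time of 48 h; a lower number here means a stronger inhibitor, a higher number a weaker inhibitor. Compound 2 `COc1ccc(-n2cc(NC(=O)c3cccc(NS(=O)(=O)c4ccccc4)c3)cn2)cc1` differs from compound 1 by methoxy in place of methyl on an aromatic carbon and in this assay compound 2 gives 42200 nM; the step is a 14-fold higher number from compound 1 to compound 2 (1.13 log units; beyond the scatter). Compound 3 `Cc1ccc(-n2cc(NC(=O)c3ccc(NS(=O)(=O)c4ccccc4)cc3)cn2)cc1` has the same atoms as compound 1 joined differently; the difference between the two cores is not broken down here. In this assay compound 3 gives 27900 nM, which sits close to the number of compound 2 and well away from that of compound 1.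

Compound 4 `COc1ccc(-n2cc(NC(=O)c3ccc(NS(=O)(=O)c4ccccc4)cc3)cn2)cc1` is not yet measured. It stands to compound 3 as compound 2 stands to compound 1: the change is methoxy in place of methyl on an aromatic carbon, and its place reads the same as for the earlier pair, so it is the same change made on the core of compound 3. Going by the values given here, only one measured instance of this change is known, the step from compound 1 to compound 2, and how it carries over to a different core cannot be checked against anything else here. Among the compounds with values here, the expectation for compound 4 is therefore a step in the same direction, written as a 7.2-fold higher number from compound 3 to compound 4 (0.86 log units; beyond the scatter), with the size taken from the single earlier step but held somewhat short of it because the starting number of compound 3, 27900 nM, already lies high. Compound 4 is estimated at 200000 nM, with a likely range from 50000 nM to 600000 nM; a run in which the assay reports only a limit is a real possibility.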

Compound 4, half-maximal inhibitory concentration: 47200 nM
Estimate against measurement, compound 4: 4.2-fold (0.63 log units) above; measured number below the stated range.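

On the core of compound 3, methoxy in place of methyl gives a 1.7-fold higher number from compound 3 to compound 4 (0.23 log units; within the scatter) in this assay, so the large rise seen on the core of compound 1 does not carry over in size, and a step measured on one core is a poor guide to the step on the other in this series. The two steps differ by more than repeated measurements would explain: the same change on two cores in this assay, a 14-fold higher number (1.13 log units; beyond the scatter) from compound 1 to compound 2 and a 1.7-fold higher number (0.23 log units; within the scatter) from compound 3 to compound 4, 8.0-fold (0.90 log units) apart, beyond the scatter of two such steps. This shows that the size of the change depends on the core in this one matched pair of pairs, but it does not show which feature of the cores sets that size, and with a step within the scatter on the core of compound 3, it does not establish a shared direction.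

The compounds shown leave open how a chlorine, an amine or a carboxylic acid in place of the methyl would read on either core, and so whether the core of compound 1 responds to other replacements as strongly as it does to methoxy. Also open, from the compounds shown here alone, is whether a longer chain such as ethyl or propyl at that place would hold the number of compound 1 at 3120 nM or lose it as methoxy does.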